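The source may report more compounds than this note shows. Statements on the series, on what has been measured and on what is new or still open speak of the compounds shown alone.

Measured so far in a toxicity assay on THP-1 cells (Homo sapiens) for inhibition; on this read-out lower numbers stand for higher toxicity in this test and higher numbers for lower toxicity in this test:
- compound 1 `COc1ccc(-c2cnc(NC(=O)c3cccc(OC)c3)n2C)cc1` gives > 100000 nM
- compound 2 `Cn1c(-c2cccc(F)c2)cnc1NC(=O)c1ccc(F)cc1` gives 58000 nM
- compound 3 `Cc1ccc(C(=O)Nc2ncc(-c3ccccc3)o2)cc1` gives 26000 nM

The value of compound 1 is a limit of this assay, not a number; it is the only one of the three that ends at the limit of > 100000 nM in this assay, at which 1 of the 3 values shown sits. Compound 2 and compound 3 give numbers, and both sit within the weakly toxic part of the range covered here. Among the measured compounds shown here, no two of the measured compounds differ in a single place, so no measured step is available to calibrate the change that leads to compound 4.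

Compound 4 `COc1ccc(-c2cnc(NC(=O)c3ccc(O)cc3)n2C)cc1` is not yet measured in this assay. It differs from compound 1 by 4-hydroxyphenyl in place of 3-methoxyphenyl on a carbonyl carbon. Compound 1 shows only a limit, so the change can be judged only against where that limit stands; there is no shown step of this kind in the series.

The expectation is that compound 4 stays in the same weakly toxic region as compound 1, with a step of a number no higher from compound 1 to compound 4 (the limit leaves the size open) that is not expected to go beyond the usual scatter in either direction. For compound 4 the estimate in this assay is 100000 nM, with a range from 30000 nM to 300000 nM, and a fair chance that the assay again reports only a limit.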

Compound 4, half-maximal cytotoxic concentration: > 100000 nM
Compound 4 gave a limit, no number; the forecaster's own chance of this, stated with the estimate: 55%; the middle value sits exactly at the limit.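

In this assay compound 4, like compound 1, ends at a limit and not at a number, and no step between the two can be read: the limit of > 100000 nM in this assay, at which 2 of the 4 values shown sit.

The compounds shown leave open whether 4-hydroxyphenyl in place of 3-methoxyphenyl on a carbonyl carbon changes this read-out at all, and in which direction.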